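Chloro in place of hydrogen on compound 2

The source may report more compounds than this note shows. Statements on the series, on what has been measured and on what is new or still open speak of the compounds shown alone.

Measured compounds, with their concentrations for half-maximal growth inhibition:
- compound 1 `COc1c(C(=O)/C=C/c2ccc(Cl)cc2)c(O)c(Br)c2occc12`: 1760 nM
- compound 2 `C=CCc1c(O)c(C(=O)/C=C/c2ccccc2)c(OC)c2ccoc12`: 5960 nM

The read-out is a functional assay on COLO 205 cells (Homo sapiens) for inhibition, with a stated time of 48 h; on this read-out lower numbers stand for stronger inhibition of growth and higher numbers for weaker inhibition of growth. Of the two measured compounds, compound 2 has the higher number at 5960 nM, and compound 1 lies lower at 1760 nM, a gap beyond the scatter.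

The next compound is compound 3 `C=CCc1c(O)c(C(=O)/C=C/c2ccc(Cl)cc2)c(OC)c2ccoc12`. It is compound 2 with chloro in place of hydrogen on an aromatic carbon, which turns phenyl into 4-chlorophenyl: chloro in place of hydrogen on an aromatic carbon. For the measured compounds named here, no pair of measured compounds shows this change alone. Compound 1 carries the 4-chlorophenyl but also differs from compound 2 elsewhere, so it offers only a weak guide. Given that compound 1 gives 1760 nM, a modest move to a lower number is expected in this assay, slightly beyond the scatter. The estimated step of a 2.3-fold lower number from compound 2 to compound 3 (0.36 log units; beyond the scatter) is therefore small and uncertain. For compound 3 the estimated value is 2600 nM, with an expected range of 1000 nM to 6500 nM.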

Compound 3, concentration for 50% growth inhibition: 4440 nM
For compound 3 the middle estimate is 1.7-fold (0.23 log units) below the measured one; the measured number falls inside the stated range.
By their numbers in this assay, from the lowest: compound 1; then compounds 3 and 2 (each within the scatter of the next).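

In this assay, chloro in place of hydrogen on an aromatic carbon, para to a large group, turns phenyl into 4-chlorophenyl and gives a 1.3-fold lower number from compound 2 to compound 3 (0.13 log units; within the scatter), so this change does not separate the two compounds on the allyl-bearing core. With the 4-chlorophenyl common to both compounds, allyl in place of bromo on an aromatic carbon gives a 2.5-fold higher number from compound 1 to compound 3 (0.40 log units; beyond the scatter), and of the two single changes now readable, only this one lies beyond the scatter. Nothing available bears on the reason for either result.

Still open, as far as these compounds go, is whether a fluoro, methoxy or nitrile group in place of the chloro would move the number beyond the scatter, and whether the swap from phenyl to 4-chlorophenyl would read the same with bromo in place of allyl. Also open, from the compounds shown here alone, is where a propyl chain, a longer alkyl chain or an amine would fall if placed on the aromatic carbon that carries allyl in compound 3 and bromo in compound 1.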